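This account rests on a few compounds, and the source may have more. Where it says the series, first, only, none or still open, it means among the compounds named here.

Measured so far:
Compound 1 `CC(O)(COc1ccc(S(F)(F)(F)(F)F)cc1)C(=O)Nc1ccc(S(F)(F)(F)(F)F)cc1`: 9800 nM
Compound 2 `CC(O)(COc1ccc(S(F)(F)(F)(F)F)cc1)C(=O)Nc1cc(C(F)(F)F)cc(C(F)(F)F)c1`: 1900 nM

In a functional assay on LNCaP cells (Homo sapiens) for antiproliferative activity, read by propidium iodide staining, with a stated time of 96 h (on this read-out lower numbers stand for stronger inhibition and higher numbers for weaker inhibition), compound 2 gives 1900 nM, the lower of the two numbers, and compound 1 gives 9800 nM, a gap beyond the usual scatter. Compound 3 `CC(O)(COc1ccc(C(F)(F)C(F)(F)F)cc1)C(=O)Nc1cc(C(F)(F)F)cc(C(F)(F)F)c1` keeps the rest of compound 2 and alters one group: a group of 7 heavy atoms (2 carbon, 5 fluorine; no ring) in place of a group of 6 heavy atoms (5 fluorine, 1 sulfur; no ring), on an aromatic carbon. The change sits on an aromatic carbon, para to a large group. Among the compounds with values here, neither measured compound carries the entering group, so no measured step shows what this exchange does. Both groups are ringless and uncharged, and with no evidence pointing either way, no change beyond the scatter is expected, and no direction can be favoured. The expectation therefore starts from compound 2 at 1900 nM. The estimated change is small: a 1.2-fold higher number from compound 2 to compound 3 (0.06 log units; within the scatter). For compound 3 the estimated value is 2200 nM, with an expected range from 800 nM to 6000 nM.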

Compound 3, half-maximal inhibitory concentration: 2700 nM
Estimate against measurement, compound 3: 1.2-fold (0.09 log units) below, and the stated range covers the measured number.
By their numbers in this assay, from the lowest: compounds 2 and 3 (each within the scatter of the next); then compound 1.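

At this position, an aromatic carbon para to a large group, the 1,1,2,2,2-pentafluoroethyl group can stand in for the group of sulfur and fluorine atoms: in this assay the exchange gives a 1.4-fold higher number from compound 2 to compound 3 (0.15 log units; within the scatter) and so leaves the two compounds indistinguishable on this read-out. Within the data shown here, this is the first direct look at this position, as the earlier pair differed elsewhere, and it shows that a group with carbon in place of sulfur, and no ring, can sit here without a step beyond the scatter. Nothing measured explains why the two groups read alike.

Going by these compounds, it remains open whether a quite different group here, such as an amine, a carboxylic acid or a nitrile, would shift the number beyond the scatter. Also open, on these data alone, is whether the same exchange elsewhere in the molecule would read the same way.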